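Methoxy to hydroxy on the aryl ring of compound 1

The source may hold more compounds than are shown below. What is called first, only, known or untested is meant among the compounds shown, and "the series" means these compounds.

Measured compounds:
compound 1 `COc1cc(C)cc(-c2nn(CC#N)cc2-c2ccnc(-c3ccc(N(C)C)cc3)c2)c1` — 61%
compound 2 `COc1cc(C)cc(-c2nn(CC#N)cc2-c2ccc(-c3cccc(C(C)=O)c3)nc2)c1` — 80%

In a functional assay on K562 cells (Homo sapiens) for cytotoxicity, read by sulforhodamine B assay, with a stated time of 48 h, tested at 0.01 uM (on this read-out higher numbers stand for a weaker effect at the one concentration tested and lower numbers for a stronger effect), compound 1 gives 61%, the lowest of the two numbers recorded. Compound 2 gives 80%, a higher number, beyond the usual scatter; the two compounds differ in more than one place, so no single step can be read from them.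

Compound 3 `Cc1cc(O)cc(-c2nn(CC#N)cc2-c2ccnc(-c3ccc(N(C)C)cc3)c2)c1` has not yet been measured in this assay. It differs from compound 1 by hydrogen in place of methyl on an oxygen on an aromatic ring.

Among the compounds with values here, no measured pair shows the effect of this change, so there is nothing to rest a direction on. The expectation is a step of a number 4 percentage points higher from compound 1 to compound 3 (within the scatter), not beyond the scatter. Compound 3 is therefore estimated at 65%, with a range from 50% to 80%.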

Compound 3, a percentage reported as activity, at one concentration (the size of the read-out at that concentration, not a potency): 101%
Beside the measured number, compound 3's estimate is 36 percentage points below it, and the stated range ends below it.
By their numbers in this assay, from the lowest: compound 1; then compound 2; then compound 3.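

In this assay, within the data shown here, going from methoxy to hydroxy on the aryl ring gives a number 40 percentage points higher from compound 1 to compound 3 (beyond the scatter), the first single-place step. The shared core, the nitrile-bearing chain and the dimethylamino-substituted aryl group are unchanged, so this step belongs to the methyl on the oxygen alone: its replacement by hydrogen leaves a clearly weaker effect at the one concentration tested, with compound 3 at 101%. The data offer no measured basis for explaining this step.

Still open, as far as these compounds go, is whether other groups on this oxygen, such as ethyl or a longer chain, would keep the effect of compound 1, and whether an amine in place of the methoxy would do the same. Also open, from the compounds shown here alone, is whether the same step appears on the core of compound 2.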